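A few compounds are considered here, and "the series" means these few. Any claim that something is new, unique, unknown or untested is made for them only; others in the source may bear on it.

In an ADME assay (liver) for metabolic stability, with Liver microsome (Rattus norvegicus) as the target, read by LC-MS, using microsomes and NADPH, with stated times of 5 min and 60 min, tested at 4 uM (on this read-out higher numbers stand for a more stable compound and lower numbers for a less stable compound), compound 1 `Cc1cc(C(=O)O)ccc1OCCCCOc1ccc(C(=O)CC(C)C)c(O)c1C` gives 41% and compound 2 `Cc1c(OCCCCOc2ccc(C(=O)O)cc2F)ccc(C(=O)CC(C)C)c1O` gives 57% as the higher of the two numbers. Compound 3 `Cc1c(OCCCCOc2ccc(C(=O)O)cc2)ccc(C(=O)CC(C)C)c1O` is still unmeasured and differs from compound 2 by hydrogen in place of fluoro on an aromatic carbon. Among the measured compounds shown here, one measured step bears on this, fluoro in place of methyl on an aromatic carbon: the step of a number 16 percentage points higher from compound 1 to compound 2 (beyond the scatter) is modest and beyond the scatter. Part of that rise could be lost with the fluoro, so the expected change is small and downward (a number 6 percentage points lower from compound 2 to compound 3 (within the scatter)). Compound 3 is estimated at 51% (expected range 37% to 65%).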

Compound 3, percent of the compound remaining: 66%
Estimate against measurement, compound 3: 15 percentage points below, and the stated range ends below it.
By their numbers in this assay, from the lowest: compound 1; then compounds 2 and 3 (each within the scatter of the next).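

In this assay, the change from 4-carboxy-2-fluorophenyl to 4-carboxyphenyl gives a number 9 percentage points higher from compound 2 to compound 3 (within the scatter), so on this read-out fluoro and hydrogen on this aromatic carbon cannot be told apart. Hydrogen in place of methyl at the same carbon gives a number 25 percentage points higher from compound 1 to compound 3 (beyond the scatter), which means that the gain seen with fluoro does not need fluoro itself: among these three compounds, only the methyl compound stands apart. The data shown offer no explanation for this difference.

The compounds shown leave open how a chlorine atom or a methoxy group on this carbon would read.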